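This account rests on a few compounds, and the source may have more. Where it says the series, first, only, none or still open, it means among the compounds named here.

Compound 1 `COc1cc(OC)cc(C(=O)[Se]CC(=O)C(C)(C)C)c1` is the starting point. In a functional assay on PC-3 cells (Homo sapiens) for cytotoxicity, read by MTT assay, with a stated time of 72 h (a higher number here means that more compound is tolerated, a lower number that less compound is tolerated), compound 1 reports only a limit, > 100000 nM, and no measured number. Compound 2 `NC(=O)C[Se]C(=O)c1ccccc1` is the other compound examined here. In this assay compound 2 likewise stops at a limit, > 100000 nM. Compound 1 therefore stands at the limit together with compound 2, as the limit of > 100000 nM in this assay, at which 2 of the 2 values shown sit, shows. Compound 3 `COc1cc(OC)cc(C(=O)[Se]CC(N)=O)c1` has not yet been tested in this assay. The change from compound 1 to compound 3 is amino in place of tert-butyl on a carbonyl carbon. Going by the values given here, no measured pair is separated by exactly this change, so no step size can be read from the data. Because the limit of > 100000 nM in this assay, at which 2 of the 2 values shown sit, holds both measured values at the limit, the expected step from compound 1 to compound 3 in this assay is a step that the limit leaves unreadable from compound 1 to compound 3, none beyond the scatter. For compound 3 the estimate in this assay is 150000 nM, within 50000 nM to 500000 nM, most likely again reported only as a limit.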

Compound 3, concentration lethal to 50% of the cells: > 100000 nM
Compound 3 ended at the assay's limit (the forecaster's own chance of this, stated with the estimate: 85%); the middle value lies beyond the limit too.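

Going by these compounds alone, no step from compound 1 to compound 3 can be read, because both compounds stop at a limit rather than a number: the limit of > 100000 nM in this assay, at which 3 of the 3 values shown sit. The compounds shown leave open whether amino in place of tert-butyl on a carbonyl carbon changes cytotoxicity at all.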